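This account rests on a few compounds, and the source may have more. Where it says the series, first, only, none or still open, it means among the compounds named here.

Measured so far in a physicochemical assay for lipophilicity, read by HPLC, at pH 7.5; on this read-out higher numbers stand for higher lipophilicity and lower numbers for lower lipophilicity:
- compound 1 `CC[C@@H](Nc1c(C#N)c(-c2ccc(-c3cccc(C)c3)cc2)nc2cnccc12)C(N)=O`: 3
- compound 2 `CC[C@@H](Nc1c(C#N)c(-c2ccc(-c3ccncc3C)cc2)nc2cnccc12)C(N)=O`: 2
- compound 3 `CC[C@@H](Nc1c(C#N)c(-c2ccc(Br)cc2)nc2cnccc12)C(=O)O`: 1.6

Compound 2 stands second highest of the three, below compound 1 and above compound 3, with both gaps beyond the scatter. The next compound is compound 4 `CC[C@@H](Nc1c(C#N)c(-c2ccc(-c3ccc(F)cc3)cc2)nc2cnccc12)C(N)=O`, and the change is 4-fluorophenyl in place of 3-methylpyridin-4-yl on an aromatic carbon. In words, 4-fluorophenyl replaces 3-methylpyridin-4-yl on an aromatic carbon of a six-membered aromatic ring of carbon only, para to a large group.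

Among the measured compounds shown here, one measured step bears on this: a number 1.00 log units lower from compound 1 to compound 2 (beyond the scatter), a modest step beyond the scatter, with 3-methylpyridin-4-yl replacing 3-methylphenyl. For the measured compounds named here, the step to compound 4 removes the same 3-methylpyridin-4-yl and restores a ring of carbon only, so it resembles that step in reverse, although no measured compound carries 4-fluorophenyl. A rise of similar size is therefore expected in this assay, and the estimated step is a number 0.90 log units higher from compound 2 to compound 4 (beyond the scatter). Compound 4 is estimated at 2.9, with an expected range of 2.5 to 3.3.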

Compound 4, distribution coefficient: 2.7
For compound 4 the middle estimate is 0.20 log units above the measured one, and the stated range covers the measured number.
By their numbers in this assay, from the lowest: compound 3; then compound 2; then compounds 4 and 1 (each within the scatter of the next).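

In this assay the exchange gives a number 0.70 log units higher from compound 2 to compound 4 (beyond the scatter) and so shows a second ring of carbon only standing clear of 3-methylpyridin-4-yl at this aromatic carbon, with the earlier drop no longer resting on a single pair. The other new comparison gives a number 0.30 log units lower from compound 1 to compound 4 (within the scatter) and leaves 4-fluorophenyl and 3-methylphenyl unseparated, so among the three compounds with a ring here, only the ring with a hetero atom, in compound 2, stands apart. Nothing at hand accounts for this gap.

Compound 2 differs from the other two in both the ring atom and the substituent, so the shown compounds do not separate the contribution of the ring nitrogen from that of the methyl or fluorine. From the compounds shown here alone, how an amine or a longer chain on this ring would read also remains open.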